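The compounds below may be only part of what the source reports. "The series", "measured", "known", "first", "only" and "open" are said of these compounds alone.

Measured so far in an assay on cells for activation of Cystic fibrosis transmembrane conductance regulator (Homo sapiens), read by fluorescence, with stated times of 10 min and 12 s; a higher number here means that more compound is needed for the effect, a lower number that less compound is needed:
compound 1 `CCN(CC)c1nc(Nc2ccc(C(=O)O)cc2)nc(OC(C(F)(F)F)C(F)(F)F)n1` gives 900 nM
compound 2 `CCN(CC)c1nc(Nc2ccc([N+](=O)[O-])cc2)nc(OC(C(F)(F)F)C(F)(F)F)n1` gives 18000 nM
compound 3 `CCN(CC)c1nc(Nc2ccc3[nH]ncc3c2)nc(OC(C(F)(F)F)C(F)(F)F)n1` gives 2800 nM

All three compounds share one core and differ only in the aromatic group attached to its ring nitrogen. Compound 3 stands second of the three numbers: it sits a 3.1-fold higher number from compound 1 to compound 3 (0.49 log units; beyond the scatter) and a 6.4-fold lower number from compound 2 to compound 3 (0.81 log units; beyond the scatter). The wide spread comes from a single change, a 20-fold higher number from compound 1 to compound 2 (1.30 log units; beyond the scatter).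

Compound 4 `CCN(CC)c1nc(Nc2ccc3ncoc3c2)nc(OC(C(F)(F)F)C(F)(F)F)n1` is the next variation on the same theme, differing from compound 3 as follows: 1,3-benzoxazol-6-yl in place of 1H-indazol-5-yl on a nitrogen on an aromatic ring. The change keeps the two-ring shape of the attached group but swaps a hydrogen-bond donor for a second acceptor.

Within the data shown here, two measured steps bear on this. Both steps into compound 3 were modest, which suggests that swapping one two-ring group for another of similar shape moves the number by a modest amount; the large step from compound 1 to compound 2 shows, though, that the attached group can matter greatly. The direction for compound 4 is uncertain, since the group that loses its donor resembles neither the carboxy of compound 1 nor the nitro of compound 2 closely. A modest rise in the number is therefore expected for compound 4, estimated as a 1.6-fold higher number from compound 3 to compound 4 (0.21 log units; within the scatter), giving an expected value of 4500 nM with a range from 1500 nM to 14000 nM.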

Compound 4, half-maximal effective concentration: 150 nM
Compound 4: the middle estimate sits 30-fold (1.48 log units) above what was measured, and the stated range ends above it.
By their numbers in this assay, from the lowest: compound 4; then compound 1; then compound 3; then compound 2.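

In this assay, the move from 1H-indazol-5-yl to 1,3-benzoxazol-6-yl (a 19-fold lower number from compound 3 to compound 4 (1.27 log units; beyond the scatter)) shows that two attached groups with the same ring types and the same heavy-atom count need not be interchangeable on this nitrogen. The change also puts compound 4 at the lowest number of the set, ahead of both groups with a single ring (a 6.0-fold lower number from compound 1 to compound 4 (0.78 log units; beyond the scatter); a 120-fold lower number from compound 2 to compound 4 (2.08 log units; beyond the scatter)), so a carboxy group is not required for a number lower than that of compound 1. The counts show that the change removes the hydrogen-bond donor and brings in a ring oxygen, but nothing measured here explains why the number falls.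

Compounds 3 and 4 differ at once in their ring atoms, their hydrogen-bond counts and the point at which the two-ring group is attached, so these compounds cannot tell which of these differences matters. A 1-methylindazol-5-yl group, which has no such donor, or a 1,3-benzothiazol-6-yl group, with sulfur in place of the ring oxygen, would test these differences more narrowly.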